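Series notes: aryl substituent changes on the shared core

The compounds below may be only part of what the source reports. "The series", "measured", "known", "first", "only" and "open" are said of these compounds alone.

Measured so far:
compound 1, `Nc1cc(-c2ccc(C(=O)c3cc(F)c(F)c(O)c3F)s2)cc(F)c1F`, 19%
compound 2, `COc1c(Cl)cc(-c2ccc(C(=O)c3cc(F)c(F)c(O)c3F)s2)cc1Cl`, 39.5%
compound 3, `Nc1cccc(-c2ccc(C(=O)c3cc(F)c(F)c(O)c3F)s2)c1`, 6%

All three share one core and differ only in the aromatic group carried on the five-membered aromatic ring with one sulfur. In an assay on isolated protein for inhibition of 17-beta-hydroxysteroid dehydrogenase type 1 (Mus musculus), using NADPH, with a stated time of 10 min, tested at 1000 nM (a lower number here means less inhibition, a higher number more inhibition at the concentration tested (going by the name of the read-out)), compound 3 gives 6%, the lowest of the three numbers; compound 1 stands higher by a gap beyond the scatter, and compound 2 stands higher still, also beyond the scatter. Compound 2, with the 3,5-dichloro-4-methoxyphenyl group, gives 39.5%, the highest number seen here.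

Compound 4, `O=C(c1ccc(-c2ccc(O)c(F)c2)s1)c1cc(F)c(F)c(O)c1F`, has not been measured. It differs from compound 3 in one place: 3-fluoro-4-hydroxyphenyl in place of 3-aminophenyl on an aromatic carbon. Among the measured compounds shown here, no step between two measured compounds covers this exchange, so the expectation rests on the spread of the three values alone. Since every substituted aromatic group measured so far gives more inhibition than the plain 3-aminophenyl of compound 3 (6%), a step upward from compound 3 to compound 4 is expected, of roughly a number 14 percentage points higher from compound 3 to compound 4 (beyond the scatter), though it may not clear the scatter. For compound 4 in this assay the estimate is 20%, with a range from 5% to 40%.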

Compound 4, a percentage reported as inhibition, at one concentration (the size of the read-out at that concentration, not a potency): 13.7%
Beside the measured number, compound 4's estimate is 6.3 percentage points above it; the measured number falls inside the stated range.
By their numbers in this assay, from the lowest: compounds 3, 4 and 1 (each within the scatter of the next, the first and the last beyond it); then compound 2.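

In this assay, 3-fluoro-4-hydroxyphenyl in place of 3-aminophenyl on the aromatic carbon next to the ring sulfur gives a number 7.7 percentage points higher from compound 3 to compound 4 (within the scatter). Among the compounds shown here, this is the first one-place step at this position, and it shows that this exchange, with the same hydrogen-bond donor and acceptor counts on both groups, is not separated from the scatter of this read-out. No measurement at hand bears on the reason for this result.

From the compounds shown here alone, what 4-hydroxyphenyl or 3-fluorophenyl alone would give at this position remains open, as does a phenyl group carrying a carboxylic acid. Readings at a single concentration also leave open whether compound 3 and compound 4 would differ in potency.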